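Adding a fluoro group to the benzyl of compound 3

This account rests on a few compounds, and the source may have more. Where it says the series, first, only, none or still open, it means among the compounds named here.

Compound 1 `C=C1C(=O)O[C@H]2[C@H]1CC/C(Cn1cc(Cn3cc(F)c(=O)[nH]c3=O)nn1)=C\CC[C@@]1(C)O[C@@H]21`: > 20000 nM (a limit, not a number)
Compound 2 `C=C1C(=O)O[C@H]2[C@H]1CC/C(COC(=O)CCC(=O)OCn1cc(F)c(=O)[nH]c1=O)=C\CC[C@@]1(C)O[C@@H]21`: > 20000 nM (a limit, not a number)
Compound 3 `C=C1C(=O)O[C@H]2[C@H]1CC/C(Cn1cc(Cn3cc(F)c(=O)n(Cc4ccccc4)c3=O)nn1)=C\CC[C@@]1(C)O[C@@H]21`: 8840 nM

These results come from a functional assay on Bel7402/5-FU cells (Homo sapiens) for antiproliferative activity, read by MTT assay, with a stated time of 72 h; a higher number here means a weaker inhibitor, a lower number a stronger inhibitor. Compound 3 is the only one of the three with an actual number, and it therefore gives the sole firm reference point. The other two compounds reach only a limit, as this shows: the limit of > 20000 nM in this assay, at which 2 of the 3 values shown sit.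

The next compound, compound 4 `C=C1C(=O)O[C@H]2[C@H]1CC/C(Cn1cc(Cn3cc(F)c(=O)n(Cc4ccc(F)cc4)c3=O)nn1)=C\CC[C@@]1(C)O[C@@H]21`, differs from compound 3 by a single change: fluoro in place of hydrogen on an aromatic carbon. This is fluoro in place of hydrogen on an aromatic carbon, turning benzyl to 4-fluorobenzyl.

Among the measured compounds shown here, only one measured step bears on this change: an at least 2.2-fold lower number from compound 1 to compound 3 (0.35 log units; beyond the scatter). It came with benzyl in place of hydrogen on an aromatic nitrogen, and it lies beyond the scatter. For the measured compounds named here, it shows that adding the benzyl group mattered, but no measured compound carries anything extra on that benzyl group. The size of a fluoro effect therefore remains unmeasured.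

With only this to go on, no step beyond the scatter is expected in this assay. The estimated step is a 1.1-fold lower number from compound 3 to compound 4 (0.04 log units; within the scatter). For compound 4 the expected value is 8000 nM, within an estimated range of 3500 nM to 18000 nM.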

Compound 4, half-maximal inhibitory concentration: 4860 nM
Compound 4: the middle estimate sits 1.6-fold (0.22 log units) above what was measured; measured number inside the range.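

In this assay, turning benzyl to 4-fluorobenzyl gives a 1.8-fold lower number from compound 3 to compound 4 (0.26 log units; within the scatter), so the two compounds cannot be told apart in this assay. Among the compounds shown here, this is the only view so far of a group added to the benzyl itself: the earlier compounds showed that benzyl on the aromatic nitrogen mattered, but not whether that benzyl could carry anything further, and here a fluoro para to a large group is tolerated. Set against the free aromatic nitrogen, 4-fluorobenzyl in place of hydrogen gives an at least 4.1-fold lower number from compound 1 to compound 4 (0.61 log units; beyond the scatter), a step that is only a minimum, since its starting point is a limit and not a number: the limit of > 20000 nM in this assay, at which 2 of the 4 values shown sit.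

Still open, as far as these compounds go, is whether a chlorine, a methoxy group or a trifluoromethyl at this same place on the ring, or a fluoro at another place on it, would give a step beyond the scatter. Also open, from the compounds shown here alone, is how an amine or a carboxylic acid on the benzyl, or a longer chain in place of benzyl on the nitrogen, would read in this assay.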